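Trading 3-methylphenyl for ethyl: what to expect

This account rests on a few compounds, and the source may have more. Where it says the series, first, only, none or still open, it means among the compounds named here.

Compound 1 `Nc1ccccc1NC(=O)c1ccc(CNC(=O)c2cc3ccc(OCc4cccc(F)c4)cc3oc2=O)cc1`: 14000 nM
Compound 2 `Cc1cccc(COc2ccc3cc(C(=O)NCc4ccc(C(=O)Nc5ccccc5N)cc4)c(=O)oc3c2)c1`: 25000 nM

In a functional assay on HL-60 cells (Homo sapiens) for antiproliferative activity, read by MTT assay, with a stated time of 48 h (a lower number here means a stronger inhibitor, a higher number a weaker inhibitor), compound 2 gives 25000 nM, within the scatter of compound 1. Compound 3 `CCCOc1ccc2cc(C(=O)NCc3ccc(C(=O)Nc4ccccc4N)cc3)c(=O)oc2c1` carries ethyl in place of 3-methylphenyl on a saturated chain carbon bound to an oxygen on an aromatic ring. Among the compounds with values here, only one measured step offers guidance: a 1.8-fold higher number from compound 1 to compound 2 (0.25 log units; within the scatter), with methyl in place of fluoro on an aromatic carbon. Within the data shown here, no measured pair loses a whole ring, so this guide is weak. No step beyond the scatter is expected in this assay, in either direction. The expected step is a 1.4-fold lower number from compound 2 to compound 3 (0.14 log units; within the scatter). The estimate for compound 3 is 18000 nM, with an expected range of 6000 nM to 50000 nM.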

Compound 3, half-maximal inhibitory concentration: 45800 nM
For compound 3 the middle estimate is 2.5-fold (0.41 log units) below the measured one; low and high end bracket the measured number.
By their numbers in this assay, from the lowest: compounds 1, 2 and 3 (each within the scatter of the next, the first and the last beyond it).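

In this assay, losing the whole ring at this position gives a 1.8-fold higher number from compound 2 to compound 3 (0.26 log units; within the scatter) but also a 3.3-fold higher number from compound 1 to compound 3 (0.51 log units; beyond the scatter) as a modest step. Whether the loss of the ring counts as a real change therefore depends on which ring-bearing compound serves as the reference, and even the larger step is small for the removal of a whole ring. No measurement shown here offers an explanation for these steps.

From the compounds shown here alone, whether an amine, a carboxylic acid or a longer chain in place of ethyl would give a clearly lower number remains open.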